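A few compounds are considered here, and "the series" means these few. Any claim that something is new, unique, unknown or untested is made for them only; others in the source may bear on it.

Measured so far:
Compound 1, `O=S(=O)(NCCNCc1ccc(-c2ccccc2)cc1)c1cc(C(F)(F)F)cc(C(F)(F)F)c1`: 2700 nM
Compound 2, `O=S(=O)(NCCCNCc1cccc(Cl)c1)c1cc(C(F)(F)F)cc(C(F)(F)F)c1`: 4400 nM

Both numbers come from a functional assay on MIA PaCa-2 cells (Homo sapiens) for inhibition, read by MTT assay, with a stated time of 72 h; a higher number here means a weaker inhibitor of growth, a lower number a stronger inhibitor of growth. Of the two, compound 2 carries the larger one, but its gap to compound 1 lies within the usual scatter, so the two compounds cannot be told apart on this evidence. Compound 3, `O=S(=O)(NCCCNCc1ccc(Br)cc1)c1cc(C(F)(F)F)cc(C(F)(F)F)c1`, has not yet been measured. It differs from compound 2 in a single exchange: 4-bromophenyl in place of 3-chlorophenyl on a saturated chain carbon bound to an amine nitrogen. Going by the values given here, no measured pair shows an exchange of this kind, so there is no step to lean on, and nothing in the two numbers points to a large effect of such a change. The expected step is a 1.2-fold lower number from compound 2 to compound 3 (0.06 log units; within the scatter), which is expected to stay within the scatter. Compound 3 is therefore estimated at 3800 nM in this assay, with a range from 1500 nM to 9000 nM.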

Compound 3, concentration for 50% growth inhibition: 2300 nM
Compound 3: middle estimate off by 1.7-fold (0.22 log units), on the high side; the range from low to high includes it.
By their numbers in this assay, from the lowest: compounds 3, 1 and 2 (each within the scatter of the next).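

Going by these compounds alone, compound 2 and compound 3 are the first pair here that differ in one place, so this assay can now be read for a single exchange: 4-bromophenyl in place of 3-chlorophenyl on a saturated chain carbon bound to an amine nitrogen gives a 1.9-fold lower number from compound 2 to compound 3 (0.28 log units; within the scatter) and so no change that can be told from ordinary repeat variation. This one exchange swaps the halogen and also alters where it sits on the ring, so the pair cannot say what either alteration does alone. Nothing measured here speaks to the reason for this result.

The compounds shown leave open what a 4-chlorophenyl or a 3-bromophenyl would give on the same chain, which would separate the two alterations. They also leave open whether a very different group here, such as a carboxylic acid on the phenyl ring, would move the number beyond that variation.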